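The source may hold more compounds than are shown below. What is called first, only, known or untested is meant among the compounds shown, and "the series" means these compounds.

Compound 1 `C=C(C)CCC[C@]1(C)C2=CCC[C@](C)(C[C@H](O)C3=CC(=O)OC3O)[C@H]2CC[C@H]1C` and compound 3 `C=C(C)CC[C@]1(C)C2=CCC[C@](C)(C[C@H](O)C3=CC(=O)OC3O)[C@H]2CC[C@H]1C` share a core that differs only in one spot: 1-methylethenyl in place of 2-methylprop-2-en-1-yl on a saturated chain carbon, two bonds along the chain from a saturated ring carbon. In a functional assay on HL-60 cells (Homo sapiens) for antiproliferative activity, read by XTT assay, with a stated time of 72 h (a higher number here means a weaker inhibitor, a lower number a stronger inhibitor), compound 1 gives 3000 nM, and compound 3 gives 3200 nM, so a 1.1-fold higher number from compound 1 to compound 3 (0.03 log units; within the scatter). Compound 2 `C=C(C)CCC[C@]1(C)C2=CCC[C@](C)(C[C@@H](O)c3ccoc3)[C@H]2CC[C@H]1C` differs from compound 1 by the change (a group of 7 heavy atoms (5 carbon, 2 oxygen; one five-membered aromatic ring with 1 hetero atom) in place of a group of 9 heavy atoms (5 carbon, 4 oxygen; one five-membered non-aromatic ring with 1 hetero atom), on a saturated chain carbon bound to a saturated ring carbon), and in this assay compound 2 gives 31200 nM, which is a 10-fold higher number from compound 1 to compound 2 (1.02 log units; beyond the scatter). Compound 4 `C=C(C)CC[C@]1(C)C2=CCC[C@](C)(C[C@@H](O)c3ccoc3)[C@H]2CC[C@H]1C` carries the same change, at the same place, on the core of compound 3: a group of 7 heavy atoms (5 carbon, 2 oxygen; one five-membered aromatic ring with 1 hetero atom) in place of a group of 9 heavy atoms (5 carbon, 4 oxygen; one five-membered non-aromatic ring with 1 hetero atom), on a saturated chain carbon bound to a saturated ring carbon. Here the expected step is a 10-fold higher number from compound 3 to compound 4 (1.00 log units; beyond the scatter), because it rests on the earlier step of a 10-fold higher number from compound 1 to compound 2 (1.02 log units; beyond the scatter) seen on compound 1, whose core differs from that of compound 3 only in the way already described. Compound 4 is therefore estimated at 32000 nM, with a likely range from 12000 nM to 85000 nM.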

Compound 4, half-maximal inhibitory concentration: 28700 nM
For compound 4 the middle estimate is 1.1-fold (0.05 log units) above the measured one, within the range that was stated.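

In this assay, putting (furan-3-yl)(hydroxy)methyl in place of the ring-bearing group gives a 9.0-fold higher number from compound 3 to compound 4 (0.95 log units; beyond the scatter), which matches the same change on the other core: the same change on two cores in this assay, a 10-fold higher number (1.02 log units; beyond the scatter) from compound 1 to compound 2 and a 9.0-fold higher number (0.95 log units; beyond the scatter) from compound 3 to compound 4, 1.2-fold (0.06 log units) apart, within the scatter of two such steps. Putting 1-methylethenyl in place of 2-methylprop-2-en-1-yl gives a 1.1-fold lower number from compound 2 to compound 4 (0.04 log units; within the scatter), so this change also behaves alike on both cores: the same change on two cores in this assay, a 1.1-fold higher number (0.03 log units; within the scatter) from compound 1 to compound 3 and a 1.1-fold lower number (0.04 log units; within the scatter) from compound 2 to compound 4, 1.2-fold (0.06 log units) apart, within the scatter of two such steps. Within these compounds, the two changes therefore add up independently, but this does not show why, nor that the same would hold on any other core.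

Going by these compounds, it remains open which part of the departing group matters for activity. On these data alone, it is also open whether a carboxylic acid at that place, or a longer chain, would fit the same pattern.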